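Series notes: carbonyl substituent swap on the shared core

The source may report more compounds than this note shows. Statements on the series, on what has been measured and on what is new or still open speak of the compounds shown alone.

Compound 1 `CCn1c(C(=O)NCCN(C)C)ccc1C(CC)(CC)c1ccc(OCC(O)C(C)(C)C)c(C)c1` is the lower of the two numbers recorded so far: in a functional assay on Caco-2 cells (Homo sapiens), read by MTT assay, with a stated time of 48 h (on this read-out lower numbers stand for stronger inhibition and higher numbers for weaker inhibition), compound 1 gives 1300 nM. Going by the values given here, compound 2 `CCn1c(C(=O)N(C)CC(=O)O)ccc1C(CC)(CC)c1ccc(OCC(=O)C(C)(C)C)c(C)c1` gives 35900 nM, a weaker result that lies beyond the scatter; the two compounds differ in more than one place, so no single step is drawn between them. Compound 3 `CCn1c(C(=O)OCc2ccc(F)cc2)ccc1C(CC)(CC)c1ccc(OCC(O)C(C)(C)C)c(C)c1` carries the change ((4-fluorobenzyl)oxy in place of (2-(dimethylamino)ethyl)amino on a carbonyl carbon). Among the compounds with values here, no measured pair shows this change, so the expected step of a 2.2-fold higher number from compound 1 to compound 3 (0.33 log units; beyond the scatter) is a modest loss, barely beyond the scatter, with wide uncertainty. Compound 3 is estimated at 2800 nM, within 600 nM to 13000 nM.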

Compound 3, half-maximal inhibitory concentration: > 50000 nM
Compound 3: only a limit was reported; the forecaster's own chance of this, stated with the estimate: 5%; middle value at least 17-fold (1.25 log units) from the limit.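

In this assay, this carbonyl position does not tolerate every substituent: (4-fluorobenzyl)oxy in place of (2-(dimethylamino)ethyl)amino gives an at least 38-fold higher number from compound 1 to compound 3 (1.58 log units; beyond the scatter). Compound 3 stands at a limit of the assay, so the step is a minimum and not a measured size: the limit of > 50000 nM in this assay, at which 1 of the 3 values shown sits. The earlier compounds shown here differ in more than one place and could not isolate this carbonyl substituent. As far as these compounds go, whether the loss tracks the ester link, the lost tertiary amine or the added aromatic ring stays open. A (4-fluorobenzyl)amino group on the same carbonyl would separate the link from the ring.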